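Methoxy on the aryl ring across two porcupine cores

The compounds below may be only part of what the source reports. "The series", "measured", "known", "first", "only" and "open" are said of these compounds alone.

Compound 1, `COc1ccccc1-n1c(SCC(=O)Nc2nc3ccc(C(F)(F)F)cc3s2)nc2c(c1=O)SCC2` — in an assay on L cells for inhibition of Protein-serine O-palmitoleoyltransferase porcupine (Mus musculus), read by reporter gene assay, with a stated time of 24 h (a lower number here means that less compound is needed, a higher number that more compound is needed for the effect), compound 1 gives 30 nM.
Compound 2, `O=C(CNC(=O)c1nn(-c2ccccc2)c(=O)c2ccccc12)Nc1nc2ccc(Cl)cc2s1` — in this assay compound 2 gives 30 nM.
Compound 3, `O=C(CSc1nc2c(c(=O)n1-c1ccccc1)SCC2)Nc1nc2ccc(C(F)(F)F)cc2s1` — in this assay compound 3 gives 40 nM.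

Compound 1 and compound 3 share one core, and compound 1 differs from compound 3 by methoxy in place of hydrogen on an aromatic carbon. That step, a 1.3-fold lower number from compound 3 to compound 1 (0.12 log units; within the scatter), lies within the scatter; the two values cannot be ordered.

Compound 2 has a different core, and how the two cores differ is not broken down here. Compound 4, `COc1ccc(-n2nc(C(=O)NCC(=O)Nc3nc4ccc(Cl)cc4s3)c3ccccc3c2=O)cc1`, has not been measured in this assay. It differs from compound 2 by methoxy in place of hydrogen on an aromatic carbon. This is the same kind of change as from compound 3 to compound 1, though in compound 4 the methoxy stands para to a large group, where in compound 1 it stands ortho to a large group.

Since a 1.3-fold lower number from compound 3 to compound 1 (0.12 log units; within the scatter) stayed within the scatter, the account expects a step of about a 1.1-fold lower number from compound 2 to compound 4 (0.03 log units; within the scatter) from compound 2 to compound 4 in this assay. Compound 4 is thus estimated at 28 nM, with a range from 12 nM to 65 nM.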

Compound 4, half-maximal effective concentration: 15 nM
The estimate for compound 4 lay 1.9-fold (0.27 log units) above the measured number; the range from low to high includes it.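

On the second core the change gives a 2.0-fold lower number from compound 2 to compound 4 (0.30 log units; within the scatter), and in this assay the two steps can be set side by side: the same change on two cores in this assay, a 1.3-fold lower number (0.12 log units; within the scatter) from compound 3 to compound 1 and a 2.0-fold lower number (0.30 log units; within the scatter) from compound 2 to compound 4, 1.5-fold (0.18 log units) apart, within the scatter of two such steps. Methoxy in place of hydrogen on the aryl ring therefore carries from one core to the other without the two steps being told apart, and neither step lies beyond the scatter. This does not show that the change has a real effect on either core, nor that the two cores respond alike, and the comparison is not clean, as the methoxy in compound 4 stands para to a large group and the methoxy in compound 1 stands elsewhere on the ring.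

The compounds shown leave open whether methoxy at one and the same place on both cores would give matching steps. They also leave open whether another group on this aryl ring, such as an amine, a carboxylic acid or a longer alkoxy chain, would give a step beyond the scatter on either core.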